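Notes on the group at the amide-type nitrogen

The source may hold more compounds than are shown below. What is called first, only, known or untested is meant among the compounds shown, and "the series" means these compounds.

Measured in a functional assay on A549 cells (Homo sapiens) for antiproliferative activity, read by MTT assay; a lower number here means a stronger inhibitor, a higher number a weaker inhibitor:
- compound 1 `COc1cc2c(Oc3ccc(NC(=O)Nc4ccc(C(F)(F)F)cc4Cl)cc3)ccnc2cc1OCCCCCCC(=O)NO`: 970 nM
- compound 2 `COc1cc2c(Oc3ccc(NC(=O)Nc4ccccc4F)cc3)ccnc2cc1OCCCCCCC(=O)NO`: 870 nM
- compound 3 `COc1cc2c(Oc3ccc(NC(=O)Nc4ccc(C)cc4C)cc3)ccnc2cc1OCCCCCCC(=O)NO`: 5490 nM

Compound 1 sits with the lower pair of numbers: the nearest measured step is a 1.1-fold lower number from compound 1 to compound 2 (0.05 log units; within the scatter), and the furthest is a 5.7-fold higher number from compound 1 to compound 3 (0.75 log units; beyond the scatter).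

The unmeasured compound 4 `COc1cc2c(Oc3ccc(NC(=O)N/N=C/c4ccccc4F)cc3)ccnc2cc1OCCCCCCC(=O)NO` loses the 2-chloro-4-(trifluoromethyl)phenyl of compound 1 and gains a group with no common name: a group of 9 heavy atoms (7 carbon, 1 nitrogen, 1 fluorine; one six-membered aromatic ring of carbon only) in place of a group of 11 heavy atoms (7 carbon, 3 fluorine, 1 chlorine; one six-membered aromatic ring of carbon only), on an amide-type nitrogen. The entering group also brings 1 double bond outside aromatic rings.

Three measured steps change the group at this place. Besides the two above, there is a 6.3-fold higher number from compound 2 to compound 3 (0.80 log units; beyond the scatter). Among the compounds with values here, one therefore lies within the scatter and two are modest, but none of the measured compounds carries this double bond, so the data offer no direct precedent. A small shift towards a higher number is expected, and the estimated step is a 1.5-fold higher number from compound 1 to compound 4 (0.19 log units; within the scatter). For compound 4 the expected value is 1500 nM, with an estimated range of 500 nM to 5000 nM.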

Compound 4, half-maximal inhibitory concentration: 7780 nM
Compound 4: middle estimate off by 5.2-fold (0.71 log units), on the low side; measured number outside the range, above it.
By their numbers in this assay, from the lowest: compounds 2 and 1 (each within the scatter of the next); then compounds 3 and 4 (each within the scatter of the next).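

In this assay, the entering group on the amide-type nitrogen gives an 8.9-fold higher number from compound 2 to compound 4 (0.95 log units; beyond the scatter) even though it retains the 2-fluorophenyl ring of compound 2, so at this position the ring alone does not set the number. The change from the 2-chloro-4-(trifluoromethyl)phenyl gives an 8.0-fold higher number from compound 1 to compound 4 (0.90 log units; beyond the scatter) and moves compound 4 away from the lower pair, while a 1.4-fold higher number from compound 3 to compound 4 (0.15 log units; within the scatter) places it with the 2,4-dimethylphenyl compound. Nothing shown here accounts for the size of these steps.

The compounds shown leave open whether these steps follow the double bond or the added nitrogen, as no group here carries only one of the two. A benzyl group on this nitrogen, or a saturated link to the same ring, would separate them.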